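Adding a 2-(methylsulfanyl)ethyl Arm to Compound 1

A few compounds are considered here, and "the series" means these few. Any claim that something is new, unique, unknown or untested is made for them only; others in the source may bear on it.

Compound 1, `O=C(CN(c1ncnc2c1ncn2C1CCCCO1)C1CC1)NCC(=O)OCc1ccccc1`, was tested in a functional assay on the whole organism (Tail, strain ICR) with Mus musculus as the target, in the tail flick test, with a stated time of 150 min, at a dose of 25 umol/kg by the oral route (a higher number here means a stronger effect of the compound at the dose given, a lower number a weaker effect), where compound 1 gives 7.26%. Among the three measured compounds it sits in the middle of the numbers: its nearest neighbour is compound 3, `CC(C)C[C@H](NC(=O)CN(c1nc(Cl)nc2[nH]cnc12)C1CC1)C(=O)OCc1ccccc1`, which in this assay gives 5.26%, and its furthest is compound 2, `NCCCC[C@H](NC(=O)CN(c1nc(Cl)nc2[nH]cnc12)C1CC1)C(=O)OCc1ccccc1`, which in this assay gives 9.88%. Both gaps fall within the usual scatter, so the three compounds cannot be told apart on this read-out.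

Compound 4, `CSCC[C@H](NC(=O)CN(c1ncnc2c1ncn2C1CCCCO1)C1CC1)C(=O)OCc1ccccc1`, has not yet been measured. It differs from compound 1 by 2-(methylsulfanyl)ethyl in place of hydrogen on a saturated chain carbon bound to an amide-type nitrogen and a carbonyl carbon. Going by the values given here, the one measured step that touches the same part of the molecule is a number 4.6 percentage points lower from compound 2 to compound 3 (within the scatter), where the group on that chain carbon was exchanged; that step stayed within the scatter. Among the compounds with values here, compounds 2 and 3 share a core that is not the core of compound 1 and compound 4, and no step between the two cores has been measured, so their values merely stand side by side with that of compound 1. On this basis no movement beyond the scatter is expected: the estimated step is a number 0.2 percentage points higher from compound 1 to compound 4 (within the scatter). Compound 4 is therefore expected to give about 7.5% in this assay, within a range from 1.5% to 14%.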

Compound 4, a percentage reported as activity, at one dose (the size of the read-out at that dose, not a potency): 17.5%
Beside the measured number, compound 4's estimate is 10 percentage points below it; the whole stated range lies below it.
By their numbers in this assay, from the lowest: compounds 3, 1, 2 and 4 (each within the scatter of the next, the first and the last beyond it).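

In this assay, the saturated chain carbon bound to an amide-type nitrogen and a carbonyl carbon now yields a step beyond the scatter, with a number 10.2 percentage points higher from compound 1 to compound 4 (beyond the scatter) on adding the 2-(methylsulfanyl)ethyl arm in place of hydrogen. The only earlier step at this carbon, a number 4.6 percentage points lower from compound 2 to compound 3 (within the scatter) on a different core, exchanged one group for another and stayed within the scatter, so the position had shown no readable movement. The new step shows that, on the core of compound 1, the read-out does respond to a group at this carbon, although this holds for a single dose and a single time point. No evidence is available on what lies behind this step.

The compounds shown leave open whether the sulfur atom matters or whether the chain alone is enough, a question that a plain butyl chain or a carboxylic acid at this carbon would address. They also leave open whether the 2-(methylsulfanyl)ethyl arm would give a similar step on the core shared by compound 2 and compound 3.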